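The source may hold more compounds than are shown below. What is called first, only, known or untested is meant among the compounds shown, and "the series" means these compounds.

The measured compounds:

Compound 1, `CCOC(COC(N)=O)C1=C(N2CC2)C(=O)C(C)=C(N2CC2)C1=O`: 6.18
Compound 2, `CC1=C(N2CC2)C(=O)C(C(C)COC(N)=O)=C(N2CC2)C1=O`: 6.41

Among these two numbers in a functional assay on L1210 cells (Mus musculus), with a stated time of 12 days (on this read-out lower numbers stand for lower potency and higher numbers for higher potency (the scale is a negative logarithm)), compound 1 stands lowest, with compound 2 as its only neighbour, and the step of a number 0.23 log units higher from compound 1 to compound 2 (within the scatter) lies within the scatter, so the two compounds are not told apart by this assay. Compound 3, `CCOC(COC(N)=O)C1=C(N2CC2)C(=O)C(CC)=C(N2CC2)C1=O`, has not yet been measured. It differs from compound 1 by methyl in place of hydrogen on a saturated chain carbon bound to a double-bonded ring carbon. Within the data shown here, no measured step touches this place or this change: the only step available, from compound 1 to compound 2, concerns a saturated chain carbon bound to a double-bonded ring carbon and a saturated chain carbon, and it is within the scatter. There is therefore no measured ground for expecting a shift beyond the scatter in this assay, and the expected step of a number 0.02 log units higher from compound 1 to compound 3 (within the scatter) is essentially none. Compound 3 is accordingly estimated at 6.2, with a range from 5.7 to 6.7, and the width of that range reflects the absence of any step on the same change.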

Compound 3, logarithm of the reciprocal of the active concentration, log(1/C): 5.76
Beside the measured number, compound 3's estimate is 0.44 log units above it, and the stated range covers the measured number.
By their numbers in this assay, from the lowest: compound 3; then compounds 1 and 2 (each within the scatter of the next).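

Read in this assay, the change from methyl to ethyl on a saturated chain carbon bound to a double-bonded ring carbon gives a modest drop (a number 0.42 log units lower from compound 1 to compound 3 (beyond the scatter)). Among these compounds, this place on the core of compound 1 is therefore not indifferent: adding a single carbon to it moves the number beyond the scatter, whereas the only earlier step (a number 0.23 log units higher from compound 1 to compound 2 (within the scatter)) involved a different place and did not separate its two compounds. The result thus gives the first measured sign in this set that the number responds to a structural change, although it rests on one pair of compounds, and no measurement given here explains the drop.

The compounds shown leave open whether a longer chain such as propyl or butyl at this place would lower the number further, and how hydrogen, a hydroxymethyl group or an aminomethyl group would read there. They also leave open whether the same change from methyl to ethyl would give a step of similar size on the core of compound 2, which carries a methyl group in place of the ethoxy group of compound 1.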